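Chlorine Removal on a Fused Core, Tested Again

The compounds below may be only part of what the source reports. "The series", "measured", "known", "first", "only" and "open" are said of these compounds alone.

Compound 1 `ClCc1ccccc1Cn1cnc2c(Cl)nc(Cl)nc21` gives 3230 nM in a functional assay on EKVX cells (Homo sapiens) for cytotoxicity, read by sulforhodamine B assay, with a stated time of 48 h; a higher number here means a weaker inhibitor of growth, a lower number a stronger inhibitor of growth. Compound 2 `ClCc1ccccc1Cn1cnc2c(Cl)ncnc21` gives 11000 nM in this assay. The step of a 3.4-fold higher number from compound 1 to compound 2 (0.53 log units; beyond the scatter) comes with the change (hydrogen in place of chloro on an aromatic carbon). Compound 3 `ClCc1ccc(Cn2cnc3nc(Cl)nc(Cl)c32)cc1` gives 3460 nM in this assay; the difference between the core of compound 3 and the core of compound 1 is not broken down here, the two having the same atoms joined differently. Compound 4 `ClCc1ccc(Cn2cnc3ncnc(Cl)c32)cc1` carries the same change relative to compound 3, namely (hydrogen in place of chloro on an aromatic carbon), at a place described in the same words as for compound 1 and compound 2. Because a 3.4-fold higher number from compound 1 to compound 2 (0.53 log units; beyond the scatter) was modest and beyond the scatter, a step of similar size is expected, a 3.3-fold higher number from compound 3 to compound 4 (0.52 log units; beyond the scatter). Compound 4 is therefore estimated at 11500 nM in this assay, expected to lie between 5500 nM and 24000 nM.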

Compound 4, concentration for total growth inhibition: 4460 nM
The estimate for compound 4 lay 2.6-fold (0.41 log units) above the measured number, and the stated range ends above it.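

In this assay, among the compounds shown here, hydrogen in place of chloro on an aromatic carbon gives a 1.3-fold higher number from compound 3 to compound 4 (0.11 log units; within the scatter), so on this core the change produces no step that can be told from the scatter. Set beside the earlier step, the two results do not differ by more than repeated measurements would allow: the same change on two cores in this assay, a 3.4-fold higher number (0.53 log units; beyond the scatter) from compound 1 to compound 2 and a 1.3-fold higher number (0.11 log units; within the scatter) from compound 3 to compound 4, 2.6-fold (0.42 log units) apart, within the scatter of two such steps. The change can thus be carried from one core to the other with no demonstrable difference in its step, but this does not show that the two steps are equal, and a single pair on each core cannot explain why only one lies beyond the scatter.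

The compounds shown leave open what an amine or a methoxy group would do in place of the chloro at this position on either core. They also leave open whether the same comparison would hold in other cell lines.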